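The source may report more compounds than this note shows. Statements on the series, on what has been measured and on what is new or still open speak of the compounds shown alone.

Working notes on the series. Compound 1 `Nc1cc(N)c2nc(-c3ccccc3)c(Oc3ccc(Cl)c(Cl)c3)nc2c1` carries a 3,4-dichlorophenoxy group on the shared core. In a functional assay on KM12 cells (Homo sapiens) for inhibition, read by sulforhodamine B assay, with a stated time of 48 h (on this read-out lower numbers stand for higher toxicity in this test and higher numbers for lower toxicity in this test), compound 1 gives < 100000 nM, which is a limit of the assay rather than a number. Compound 2 `CCOC(=O)[C@H](CCC(=O)O)NC(=O)c1ccc(Sc2nc3cc(N)cc(N)c3nc2-c2ccccc2)cc1` stands at a limit as well: in this assay compound 2 gives < 100000 nM. Compound 3 `CCOC(=O)[C@H](CCC(=O)O)NC(=O)c1ccc(Oc2nc3cc(N)cc(N)c3nc2-c2ccccc2)cc1` is the same case: in this assay compound 3 gives < 100000 nM, again a limit. Going by the values given here, because of the limit of < 100000 nM in this assay, at which 3 of the 3 values shown sit, the measured set does not separate any compound from another, and no step between measured compounds can be sized; where compound 1 stands relative to the others is therefore open.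

Compound 4 `COc1ccc(Sc2nc3cc(N)cc(N)c3nc2-c2ccccc2)cc1` is not yet measured. It differs from compound 1 by (4-methoxyphenyl)sulfanyl in place of 3,4-dichlorophenoxy on an aromatic carbon. Among the compounds with values here, with no measured step to lean on, the expectation for this change in this assay is none beyond the scatter, meaning a reading that again lands at or inside the limit. Compound 4 is expected at 20000 nM, with a range from 3000 nM to 100000 nM. The expected step in this assay is a step that the limit leaves unreadable from compound 1 to compound 4, i.e. nothing that the scatter would not cover.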

Compound 4, concentration lethal to 50% of the cells: < 100000 nM
Compound 4 ended at the assay's limit (the forecaster's own chance of this, stated with the estimate: 60%); the middle value lies beyond the limit too.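

No step from compound 1 to compound 4 can be read, because both compounds stand at a limit in this assay: the limit of < 100000 nM in this assay, at which 4 of the 4 values shown sit.

The compounds shown leave open whether compound 1, compound 2, compound 3 and compound 4 differ at all in this assay, and what (4-methoxyphenyl)sulfanyl in place of 3,4-dichlorophenoxy does to the read-out.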